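The source may report more compounds than this note shows. Statements on the series, on what has been measured and on what is new or still open speak of the compounds shown alone.

Measured so far in an ADME assay on Vero cells (Chlorocebus sabaeus) for cytotoxicity, read by resazurin assay, with a stated time of 72 h; a lower number here means a stronger inhibitor, a higher number a weaker inhibitor

- Compound 1 `Cc1ccc(C(=O)CCN2CCN(c3ccc(F)cc3)CC2)cc1` gives 55400 nM
- Compound 2 `COc1ccc(C(=O)CCN2CCN(c3ccc(F)cc3)CC2)cc1` gives 55000 nM
- Compound 3 `O=C(CCN1CCN(c2ccc(F)cc2)CC1)c1ccc(Cl)c(F)c1` gives 105000 nM

Compound 2 at 55000 nM sits within the scatter of both compound 1 and compound 3. Compound 4 `O=C(CCN1CCN(c2ccc(F)cc2)CC1)c1ccc(C(F)(F)F)cc1` has not been measured. Its difference from compound 2 is trifluoromethyl in place of methoxy on an aromatic carbon in one place: trifluoromethyl in place of methoxy on an aromatic carbon. Among the compounds with values here, no measured compound carries trifluoromethyl, so only nearby changes can guide the estimate. Methoxy in place of methyl gave a 1.0-fold lower number from compound 1 to compound 2 (0.00 log units; within the scatter) and a swap of the whole aryl group gave a 1.9-fold higher number from compound 2 to compound 3 (0.28 log units; within the scatter) in the same series. Neither step leaves the scatter, so no step beyond it is expected in this assay here. The estimated step is a 1.4-fold higher number from compound 2 to compound 4 (0.13 log units; within the scatter) for this change. For compound 4 the estimated value is 75000 nM with an expected range from 38000 nM to 150000 nM in this assay.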

Compound 4, half-maximal inhibitory concentration: 28500 nM
For compound 4 the middle estimate is 2.6-fold (0.42 log units) above the measured one; the whole stated range lies above it.
By their numbers in this assay, from the lowest: compounds 4, 2, 1 and 3 (each within the scatter of the next, the first and the last beyond it).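

In this assay, trifluoromethyl on this aromatic carbon, para to a large group, stays within the scatter of methoxy (a 1.9-fold lower number from compound 2 to compound 4 (0.29 log units; within the scatter)) and of methyl (a 1.9-fold lower number from compound 1 to compound 4 (0.29 log units; within the scatter)). Within the data shown here, this swap takes away the one hydrogen-bond acceptor of methoxy and brings in fluorine, yet no step leaves the scatter, so all three groups read alike at this place. No measurement here accounts for these numbers. On these data alone, whether an amine or a carboxylic acid at this place would give a step beyond the scatter remains open, as does any change to the shared core.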